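Changing the chain-terminal amine ring of compound 3

The source may hold more compounds than are shown below. What is called first, only, known or untested is meant among the compounds shown, and "the series" means these compounds.

Among the measured compounds shown here, compound 3 `COc1cc2c(Oc3ccc(NC(=O)c4nn(-c5ccccc5C)c(=O)cc4C)cc3F)ccnc2cc1OCCCN1CCCCC1` gives 3220 nM in a functional assay on NCI-H460 cells (Homo sapiens) for inhibition, read by MTT assay, with a stated time of 72 h (on this read-out lower numbers stand for stronger inhibition and higher numbers for weaker inhibition), the highest number among the three compounds measured so far. Compound 1 `COc1cc2c(Oc3ccc(NC(=O)c4nn(-c5ccccc5)c(=O)cc4C)cc3F)ccnc2cc1OCCCN1CCCCC1` gives 280 nM in this assay, and compound 2 `COc1cc2c(Oc3ccc(NC(=O)c4nn(-c5ccccc5C)c(=O)cc4C)cc3F)ccnc2cc1OCCCN1CCCC1` gives 1590 nM. The step of a 12-fold higher number from compound 1 to compound 3 (1.06 log units; beyond the scatter) concerns the methyl on an aromatic carbon and does not touch the chain terminus, whereas the step of a 2.0-fold higher number from compound 2 to compound 3 (0.31 log units; beyond the scatter) concerns exactly the place that is altered next. Compound 4 `COc1cc2c(Oc3ccc(NC(=O)c4nn(-c5ccccc5C)c(=O)cc4C)cc3F)ccnc2cc1OCCCN1CCN(C)CC1` differs from compound 3 by 4-methylpiperazin-1-yl in place of piperidin-1-yl on a saturated chain carbon, three bonds along the chain from an oxygen on an aromatic ring. For the measured compounds named here, only one measured step, a 2.0-fold higher number from compound 2 to compound 3 (0.31 log units; beyond the scatter), bears on this change, and it was modest, so a step in this assay of no more than modest size is expected for this exchange, and its direction cannot be read from the data with confidence. Compound 4 is therefore estimated at 2500 nM, with a range from 900 nM to 7000 nM. The corresponding step is expected to be a 1.3-fold lower number from compound 3 to compound 4 (0.11 log units; within the scatter).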

Compound 4, half-maximal inhibitory concentration: 3420 nM
Compound 4: middle estimate off by 1.4-fold (0.14 log units), on the low side; the measured number falls inside the stated range.
By their numbers in this assay, from the lowest: compound 1; then compound 2; then compounds 3 and 4 (each within the scatter of the next).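

At the chain end, on a saturated chain carbon three bonds along the chain from an oxygen on an aromatic ring, 4-methylpiperazin-1-yl and piperidin-1-yl could not be told apart in this assay, with a 1.1-fold higher number from compound 3 to compound 4 (0.03 log units; within the scatter). Among these three compounds, the pyrrolidin-1-yl of compound 2 is thus set apart from both six-membered rings, with a 2.2-fold higher number from compound 2 to compound 4 (0.33 log units; beyond the scatter) as a modest step of the same kind as a 2.0-fold higher number from compound 2 to compound 3 (0.31 log units; beyond the scatter). Nothing in the available data accounts for these numbers.

From the compounds shown here alone, whether 4-methylpiperazin-1-yl would behave the same way on the core of compound 1, which gives 280 nM, remains open. Also open, going by these compounds, is how a morpholin-4-yl ring, a dimethylamino group or a longer chain would read at this place.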